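Removing the ring fluorine from the amide side of compound 2

A few compounds are considered here, and "the series" means these few. Any claim that something is new, unique, unknown or untested is made for them only; others in the source may bear on it.

Measured so far in a functional assay on CAL-27 cells (Homo sapiens) for cytotoxicity, read by MTT assay, with a stated time of 72 h; a lower number here means a stronger inhibitor, a higher number a weaker inhibitor:
- compound 1, `Cc1cc(C)cc(C(=O)N(CC(=O)NCc2ccccc2)Cc2ccc(C(=O)Nc3cc(F)ccc3N)cc2)c1`: 5720 nM
- compound 2, `CN(C)c1ccc(C(=O)N(CCCCCC(=O)Nc2cc(F)ccc2N)CC(=O)NCc2ccccc2)cc1`: 20200 nM

Compound 2 gives the highest of the two numbers in this assay; the nearest, compound 1, lies lower, and the gap between them is beyond the scatter. Going by the values given here, no step between measured compounds that differ in one place is available, so nothing is yet known about how a single change on the aromatic ring carrying the amino group moves the number.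

Compound 3, `CN(C)c1ccc(C(=O)N(CCCCCC(=O)Nc2ccccc2N)CC(=O)NCc2ccccc2)cc1`, is the next one to be measured. It differs from compound 2 in one place: hydrogen in place of fluoro on an aromatic carbon. The fluoro leaves, a hydrogen enters, and the rest of the molecule is unchanged.

Among the compounds with values here, with no measured step of this kind to lean on, the expectation for compound 3 is a number close to that of compound 2, with a step of a 1.2-fold higher number from compound 2 to compound 3 (0.07 log units; within the scatter) that should stay within the scatter, perhaps edging toward a slightly higher number. Compound 3 is therefore estimated at 24000 nM, with a range from 10000 nM to 60000 nM.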

Compound 3, half-maximal inhibitory concentration: 16000 nM
Beside the measured number, compound 3's estimate is 1.5-fold (0.18 log units) above it; the range from low to high includes it.
By their numbers in this assay, from the lowest: compound 1; then compounds 3 and 2 (each within the scatter of the next).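

In this assay the series gains its first step in a single place: hydrogen in place of fluoro on the aromatic carbon para to an amino group gives a 1.3-fold lower number from compound 2 to compound 3 (0.10 log units; within the scatter) and stays within the scatter. With the rest of the molecule held constant, the 2-amino-5-fluorophenyl and 2-aminophenyl versions cannot be told apart in this assay, so the fluoro is not required to retain the activity of compound 2, and this one step gives no sign that the position responds to this particular change. No measurement bearing on the reason for this result is at hand.

Still open, as far as these compounds go, is whether a larger or different group on the same carbon, such as chloro, methoxy or trifluoromethyl, would move the number beyond the scatter, since fluoro and hydrogen are the only two substituents compared here. Also open, from the compounds shown here alone, is whether the same exchange of fluoro for hydrogen would read alike in compound 1, whose remaining structure differs from compound 2 in more than one place, so that this single step cannot be carried over to it.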